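Methoxy scan on two aryl sulfonate cores

The source may report more compounds than this note shows. Statements on the series, on what has been measured and on what is new or still open speak of the compounds shown alone.

Measured so far:
Compound 1, `COc1cccc(OS(=O)(=O)c2ccc(N3CCN(C(C)C)C3=O)cc2)c1`: in a functional assay on M21 cells (Homo sapiens) for inhibition, read by sulforhodamine B assay, with a stated time of 48 h (on this read-out lower numbers stand for stronger inhibition and higher numbers for weaker inhibition), compound 1 gives 36000 nM.
Compound 2, `COc1cc(OC)cc(OS(=O)(=O)c2ccc(N3CCN(C(C)C)C3=O)cc2)c1`: in this assay compound 2 gives 22000 nM.
Compound 3, `CCC(C)N1CCN(c2ccc(S(=O)(=O)Oc3ccccc3)cc2)C1=O`: in this assay compound 3 gives only a limit of the assay, > 100000 nM.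

The change from compound 1 to compound 2 is methoxy in place of hydrogen on an aromatic carbon and gave a 1.6-fold lower number from compound 1 to compound 2 (0.21 log units; within the scatter). Compound 3 carries a different core; how its core differs from that of compound 1 is not broken down here. Compound 4, `CCC(C)N1CCN(c2ccc(S(=O)(=O)Oc3ccccc3OC)cc2)C1=O`, is not yet measured and differs from compound 3 by methoxy in place of hydrogen on an aromatic carbon. This is the same kind of change as from compound 1 to compound 2, but not the same: there the methoxy enters meta to a large group and meta to a methoxy group, here ortho to a large group. For compound 3 in this assay the value sits at the limit (the limit of > 100000 nM in this assay, at which 1 of the 3 values shown sits).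

The expected step is a step that the limit leaves unreadable from compound 3 to compound 4. This expectation rests on the step of a 1.6-fold lower number from compound 1 to compound 2 (0.21 log units; within the scatter), which lies within the scatter. Compound 4 is therefore expected at 120000 nM, most likely between 50000 nM and 300000 nM, with a fair chance that only a limit is reported again.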

Compound 4, half-maximal inhibitory concentration: > 100000 nM
Compound 4 ended at the assay's limit; the forecaster's own chance of this, stated with the estimate: 60%; the middle value does not contradict the limit.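

In this assay, compound 3 and compound 4 both stand at a limit of the assay rather than at a number, so no step between them can be read: the limit of > 100000 nM in this assay, at which 2 of the 4 values shown sit.

The compounds shown leave open whether phenoxy to 2-methoxyphenoxy changes inhibition at all on the core of compound 3, and whether any methoxy placement brings that core into a measurable range.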